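The source may report more compounds than this note shows. Statements on the series, on what has been measured and on what is new or still open speak of the compounds shown alone.

Compound 1 `C/C(=N/NC(=S)Nc1ccccc1)c1ccccn1`, compound 2 `C/C(=N/NC(=S)Nc1cccc([N+](=O)[O-])c1)c1ccccn1` and compound 3 `CC(=NNC(=S)Nc1ccccc1[N+](=O)[O-])c1ccccn1` share a common core and were tested in a functional assay on T98G cells (Homo sapiens) for cytotoxicity, read by MTT assay, with a stated time of 48 h; a lower number here means a stronger inhibitor, a higher number a weaker inhibitor. In this assay compound 1 gives 6.81 nM, compound 2 gives 140 nM, and compound 3 gives 6.6 nM. Compound 2 and compound 1 differ in one place, (hydrogen in place of nitro on an aromatic carbon), and the step of a 21-fold lower number from compound 2 to compound 1 (1.31 log units; beyond the scatter) is large. Compound 3 and compound 2 are built from the same atoms joined differently; the difference between the two cores is not broken down here. Compound 4 `CC(=NNC(=S)Nc1ccccc1)c1ccccn1` has not yet been measured in this assay; it differs from compound 3 by hydrogen in place of nitro on an aromatic carbon. This is the same kind of change as that from compound 2 to compound 1, though the place differs: meta to a large group in the one case, ortho to a large group in the other. Because compound 3 already gives 6.6 nM, the step of a 1.1-fold higher number from compound 3 to compound 4 (0.03 log units; within the scatter) is expected to be small. Compound 4 is therefore estimated at 7 nM, between 3.5 nM and 14 nM.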

Compound 4, half-maximal inhibitory concentration: 6.8 nM
For compound 4 the middle estimate is 1.0-fold (0.01 log units) above the measured one, within the range that was stated.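

In this assay the replacement of nitro by hydrogen gives a 1.0-fold higher number from compound 3 to compound 4 (0.01 log units; within the scatter), so the change does not carry over from one core to the other with the same size: the same change on two cores in this assay, a 21-fold lower number (1.31 log units; beyond the scatter) from compound 2 to compound 1 and a 1.0-fold higher number (0.01 log units; within the scatter) from compound 3 to compound 4, 21-fold (1.33 log units) apart, beyond the scatter of two such steps. The two steps alone do not show why they part, or what the change would do on any further core. The step of a 1.0-fold lower number from compound 1 to compound 4 (0.00 log units; within the scatter) does not compare two defined geometries, and what separates this pair is a matter of how the structures are drawn: the fact that one of compounds 1 and 4 is drawn with a defined configuration and the other without, at the place where they differ. The compounds shown leave open whether another group on the aromatic ring, such as an amine or a methoxy group, would follow compound 2 or compound 3.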